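A few compounds are considered here, and "the series" means these few. Any claim that something is new, unique, unknown or untested is made for them only; others in the source may bear on it.

Working notes on the series.

For the measured compounds named here, compound 1 `COc1cccc(Sc2c(NS(=O)(=O)c3ccc(C(C)(C)C)cc3)noc2CCCC#N)c1` gives 1300 nM in an assay on A7R5 cells for displacement of a labelled ligand from Endothelin-1 receptor (Rattus norvegicus) (on this read-out lower numbers stand for stronger inhibition and higher numbers for weaker inhibition), the second highest of the three numbers measured so far. Compound 2 `COc1cccc(Sc2c(NS(=O)(=O)c3ccc(C(C)(C)C)cc3)noc2CCC/C=N/O)c1` gives 1500 nM and sits nearest, with a 1.2-fold higher number from compound 1 to compound 2 (0.06 log units; within the scatter). Compound 3 `COc1cccc(Sc2c(NS(=O)(=O)c3ccc(C(C)(C)C)cc3)noc2CCC=O)c1` gives 380 nM, the furthest of the three from compound 1, with a 3.4-fold lower number from compound 1 to compound 3 (0.53 log units; beyond the scatter); the same compound reached from compound 2 shows a 3.9-fold lower number from compound 2 to compound 3 (0.60 log units; beyond the scatter).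

Compound 4 `COc1cccc(Sc2c(NS(=O)(=O)c3ccc(C(C)(C)C)cc3)noc2CCCC(C)=O)c1` is the next member, differing from compound 1 by acetyl in place of cyano on a saturated chain carbon, three bonds along the chain from an aromatic carbon.

The step from compound 1 to compound 3 is the one that bears on it: a carbonyl at the chain end in place of the nitrile gave a modest lowering, although there the chain was also shortened. The step from compound 1 to compound 2, nitrile to oxime at the same chain length, stayed within the scatter. Compound 4 keeps the chain length and brings in a carbonyl, so a modest lowering is expected, probably smaller than that seen for compound 3; compound 4 is estimated at 650 nM, range 250 nM to 1600 nM, meaning an expected 2.0-fold lower number from compound 1 to compound 4 (0.30 log units; within the scatter).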

Compound 4, half-maximal inhibitory concentration: 1300 nM
Beside the measured number, compound 4's estimate is 2.0-fold (0.30 log units) below it; measured number inside the range.
By their numbers in this assay, from the lowest: compound 3; then compounds 1, 4 and 2 (each within the scatter of the next).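

At this chain length, swapping the nitrile for a ketone carbonyl gives no separation, with no change at the digits printed from compound 1 to compound 4 (within the scatter), and the oxime is no different, with a 1.2-fold lower number from compound 2 to compound 4 (0.06 log units; within the scatter). For the compounds shown here, the only new step beyond the scatter is a 3.4-fold higher number from compound 3 to compound 4 (0.53 log units; beyond the scatter), so in this assay the low number stays with compound 3 alone, and the presence of a carbonyl is not enough to give it, as compound 4 also carries one. No measurement shown here offers an explanation for this difference.

Compound 3 differs from compound 4 in both chain length and chain end, so the compounds shown leave open which of the two goes with its lower number. Going by these compounds, a formyl group on the longer chain would separate these two, and how a carboxylic acid or an amine at the chain end would read also remains open.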